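Carboxylic acid to methylamide on the shared core

A few compounds are considered here, and "the series" means these few. Any claim that something is new, unique, unknown or untested is made for them only; others in the source may bear on it.

Compound 1, `OB1OCc2ccc(-n3cccc3Sc3ccc(Cl)cc3)cc21`: in an ADME assay on L929 cells (Mus musculus) for cytotoxicity, read by resazurin assay, with a stated time of 72 h (a higher number here means a weaker inhibitor, a lower number a stronger inhibitor), compound 1 gives > 10 ug/mL, which is a limit of the assay and not a number.
Compound 2, `O=C(O)c1cccn1-c1ccc2c(c1)B(O)OC2`: in this assay compound 2 gives > 10 ug/mL, again a limit of the assay rather than a measured number.

Compound 2 therefore stands at the limit of > 10 ug/mL in this assay, at which 2 of the 2 values shown sit, so its cytotoxicity is known only as weaker than the assay can resolve, and compound 1 is in the same position. Compound 3, `CNC(=O)c1cccn1-c1ccc2c(c1)B(O)OC2`, has not yet been measured. It differs from compound 2 by methylamino in place of hydroxy on a carbonyl carbon. Within the data shown here, no step between two measured compounds is recorded, so no measured change can be consulted. Compound 3 is expected to remain close to compound 2, with a step that the limit leaves unreadable from compound 2 to compound 3 that is not beyond the usual scatter. Compound 3 is thus estimated at 15 ug/mL, within a range from 7 ug/mL to 40 ug/mL, and most likely the assay will again report only a limit.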

Compound 3, half-maximal inhibitory concentration: > 10 ug/mL
Compound 3: a limit, no number; the forecaster's own chance of this, stated with the estimate: 80%; the middle value is on the limit's open side.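

In this assay compound 3 gives > 10 ug/mL, a limit of the assay and not a number. Among these compounds, compound 2 also stands at a limit, so no step from compound 2 to compound 3 can be read. The compounds shown leave open whether going from carboxy to methylcarbamoyl changes cytotoxicity at all.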